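This account rests on a few compounds, and the source may have more. Where it says the series, first, only, none or still open, it means among the compounds named here.

Working notes on the series in an ADME assay on HEK293 cells (Homo sapiens) for cytotoxicity, with a stated time of 72 h; on this read-out higher numbers stand for an effect only at larger amounts of compound and lower numbers for an effect already at smaller amounts:

- compound 1 `C=C[C@@](C)(/C=C/c1ccc(OS(=O)(=O)C(F)(F)F)cc1)CCC=C(C)C`: > 36600 nM, a limit
- compound 2 `C=C[C@@](C)(/C=C/c1ccc(OS(=O)(=O)c2ccc(C)cc2)cc1)CCC=C(C)C`: > 36600 nM, a limit
- compound 3 `COc1ccc(/C=C/[C@@](C)(/C=C/c2ccc(O)c(C=O)c2)CCC=C(C)C)cc1`: 2270 nM

Compound 1 gives only a limit and no number. It stands at the limit of > 36600 nM in this assay, at which 2 of the 3 values shown sit, so its true position in this assay is not known.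

The next compound to be read is compound 4 `C=C[C@@](C)(/C=C/c1ccc(Nc2ccc(F)cc2)cc1)CCC=C(C)C`. The change is (4-fluorophenyl)amino in place of ((trifluoromethyl)sulfonyl)oxy on an aromatic carbon, para to a large group.

Going by the values given here, only one measured step starts from compound 1: a step that the two limits leave unreadable from compound 1 to compound 2. It gives no size to carry over, and it does not involve the group that enters here. Among the compounds with values here, the other guide is compound 3, which gives 2270 nM, the only number in the set. That value shows that a readable effect occurs in this series, but compound 3 differs from compound 4 in more than one place, so it sets no firm scale.

A move toward lower numbers is therefore expected, though another limit remains possible. The estimated step is an at least 1.8-fold lower number from compound 1 to compound 4 (0.26 log units; that floor lies within the scatter), and its size is highly uncertain. For compound 4 the expected value is 20000 nM, with an estimated range of 5000 nM to 60000 nM.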

Compound 4, half-maximal effective concentration: > 36600 nM
Compound 4: no number, only a limit; the forecaster's own chance of this, stated with the estimate: 40%; at least 1.8-fold (0.26 log units) between middle value and limit.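

In this assay compound 4 gives > 36600 nM as a limit and not a number. No step from compound 1 to compound 4 can be read, and compound 1 and compound 4 share the same limit: the limit of > 36600 nM in this assay, at which 3 of the 4 values shown sit.

The compounds shown leave open where the true values of compound 1, compound 2 and compound 4 lie.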